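The compounds below may be only part of what the source reports. "The series", "measured", "known", "first", "only" and "open" are said of these compounds alone.

Measured compounds in the series:

Compound 1 `COc1ccc([C@H]2CC(=O)N(c3ccccc3)C2)cc1OC1CCCC1` — in a functional assay on HEK293 cells (Homo sapiens) for cytotoxicity (on this read-out lower numbers stand for higher toxicity in this test and higher numbers for lower toxicity in this test), compound 1 gives > 10000 nM, which is a limit of the assay and not a number.
Compound 2 `COc1ccc([C@H]2CC(=O)N(c3cc(N)cc(N)c3)C2)cc1OC1CCCC1` — in this assay compound 2 gives > 10000 nM, again a limit of the assay.
Compound 3 `COc1ccc([C@H]2CC(=O)N(c3ccccc3N)C2)cc1OC1CCCC1` — in this assay compound 3 gives > 10000 nM, also a limit of the assay.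

Compound 2 therefore stands at the upper limit of this assay, and the other two values shown stand there as well; every value in the series is a limit (the limit of > 10000 nM in this assay, at which 3 of the 3 values shown sit).

The next compound is compound 4 `COc1ccc([C@H]2CC(=O)N(c3cccc(C)c3)C2)cc1OC1CCCC1`. Its change from compound 2 is 3-methylphenyl in place of 3,5-diaminophenyl on an amide-type nitrogen in a ring. The measured steps that touch the group on the amide-type nitrogen in the ring are a step that the two limits leave unreadable from compound 1 to compound 2, a step that the two limits leave unreadable from compound 2 to compound 3 and a step that the two limits leave unreadable from compound 1 to compound 3; none of them has a readable size, since both ends of each step are limits. No step in this assay has yet shown a change in cytotoxicity on exchanging this aryl group, so no step beyond the scatter is expected from compound 2 to compound 4, and the value is expected to remain at the limit.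

Compound 4 is estimated at 10000 nM in this assay, within 5000 nM to 30000 nM, most likely reported only as a limit.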

Compound 4, half-maximal cytotoxic concentration: > 10000 nM
Compound 4 gave a limit, no number; the forecaster's own chance of this, stated with the estimate: 85%; the middle value lies on the limit itself.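

In this assay compound 4 gives > 10000 nM, which is a limit and not a number. Within the data shown here, no step linking compound 4 with compound 1, compound 2 or compound 3 can be read, since all four compounds sit at the same limit: the limit of > 10000 nM in this assay, at which 4 of the 4 values shown sit. The compounds shown leave open whether any group on the amide-type nitrogen in the ring gives a numerical cytotoxic concentration.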